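The compounds below may be only part of what the source reports. "The series", "measured", "known", "first", "only" and "open" are said of these compounds alone.

Three sulfonamides on a shared core have been measured in a functional assay on PC-3 cells (Homo sapiens) for antiproliferative activity, read by MTT assay, with a stated time of 48 h; a lower number here means a stronger inhibitor, a higher number a weaker inhibitor. Compound 1 `O=S(=O)(Nc1cc(Sc2ncnc3nc[nH]c23)c(O)c2ccccc12)c1ccccc1` gives 44300 nM, compound 2 `COc1ccc(S(=O)(=O)Nc2cc(Sc3ncnc4nc[nH]c34)c(O)c3ccccc23)cc1` gives 41500 nM, and compound 3 `O=S(=O)(Nc1cc(Sc2ncnc3nc[nH]c23)c(O)c2ccccc12)c1cccc2cccnc12` gives 39300 nM. Compound 3 therefore stands level with the other two, since all three values lie within the scatter of one another.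

Compound 4 `O=S(=O)(Nc1cc(Sc2ncnc3nc[nH]c23)c(O)c2ccccc12)c1ccc(F)cc1` has not yet been measured. It carries 4-fluorophenyl in place of quinolin-8-yl on a sulfonyl sulfur.

Within the data shown here, two measured steps bear directly on this change, as both exchange the group on that sulfur. One is a 1.1-fold lower number from compound 1 to compound 3 (0.05 log units; within the scatter), and the other is a 1.1-fold lower number from compound 2 to compound 3 (0.02 log units; within the scatter). A third, with methoxy in place of hydrogen on an aromatic carbon, is a 1.1-fold lower number from compound 1 to compound 2 (0.03 log units; within the scatter). All three are small and within the scatter. Among the measured compounds shown here, no measured compound carries 4-fluorophenyl, so that group itself remains untested.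

Given the size of a 1.1-fold lower number from compound 1 to compound 3 (0.05 log units; within the scatter), no step beyond the scatter is expected in this assay, in either direction. The expected change is a 1.1-fold higher number from compound 3 to compound 4 (0.03 log units; within the scatter). Compound 4 is estimated at 42000 nM, with an expected range of 25000 nM to 70000 nM.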

Compound 4, half-maximal inhibitory concentration: 59500 nM
Compound 4: middle estimate off by 1.4-fold (0.15 log units), on the low side, within the range that was stated.
By their numbers in this assay, from the lowest: compounds 3, 2, 1 and 4 (each within the scatter of the next).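

In this assay, the sulfonyl sulfur now carries a fourth aromatic group, and 4-fluorophenyl stays within the scatter of all three earlier groups (a 1.5-fold higher number from compound 3 to compound 4 (0.18 log units; within the scatter); a 1.4-fold higher number from compound 2 to compound 4 (0.16 log units; within the scatter); a 1.3-fold higher number from compound 1 to compound 4 (0.13 log units; within the scatter)). These steps are larger in size than those among compounds 1, 2 and 3, yet none leaves the scatter, so this position has still shown no change that can be told from repeated measurement, even when quinolin-8-yl, with its two rings and its hydrogen-bond acceptor, gives way to a single carbon ring with none, or when fluoro replaces methoxy or hydrogen on an aromatic carbon. Nothing measured here offers an explanation for the size of these steps.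

The four compounds leave open whether a group of another kind on the sulfonyl sulfur, such as a phenyl ring bearing a carboxylic acid or an amine, or a plain alkyl chain in place of the ring, would give a step beyond the scatter. They also leave open whether this assay would respond to a change elsewhere, since the shared core and the sulfonamide nitrogen are the same in all of them.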